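A fluoro swap on a compound at the assay limit

This account rests on a few compounds, and the source may have more. Where it says the series, first, only, none or still open, it means among the compounds named here.

Measured so far in an ADME assay on Raji cells (Homo sapiens) for cytotoxicity, with a stated time of 72 h; on this read-out lower numbers stand for an effect already at smaller amounts and higher numbers for an effect only at larger amounts of compound
- compound 1 (`CSc1ccc(NC(=O)Nc2cc(C)nc3ccccc23)cc1`) gives > 25000 nM as a limit
- compound 2 (`Cc1cc(NC(=O)Nc2cccc([N+](=O)[O-])c2)c2ccccc2n1`) gives > 25000 nM as a limit
- compound 3 (`COc1ccc(NC(=O)Nc2cc(C)nc3ccccc23)cc1OC`) gives > 25000 nM as a limit

Compound 1 has no exact number, since its > 25000 nM is a limit of the assay. It shares that position with the other two compounds, as all the results so far show: the limit of > 25000 nM in this assay, at which 3 of the 3 values shown sit.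

Compound 4 (`Cc1cc(NC(=O)Nc2ccc(F)cc2)c2ccccc2n1`) has not yet been measured. It has fluoro in place of methylsulfanyl on an aromatic carbon, para to a large group: fluoro in place of methylsulfanyl on an aromatic carbon. For the measured compounds named here, no pair of measured compounds shows a single change of this kind, so the data give no direct size for this step. The three measured compounds carry different groups, yet none gives a number in this assay. A step beyond the usual scatter is therefore not expected, and compound 4 will probably also return only a limit. The estimated step is a number no higher from compound 1 to compound 4 (the limit leaves the size open). For compound 4 the estimated value is 25000 nM, with an expected range from 10000 nM to 50000 nM.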

Compound 4, half-maximal effective concentration: > 25000 nM
Compound 4: a limit, no number (the forecaster's own chance of this, stated with the estimate: 80%); the middle value sits exactly at the limit.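

Compound 1 and compound 4 each give only a limit, and the step from methylsulfanyl to fluoro between them cannot be read. All results share one position: the limit of > 25000 nM in this assay, at which 4 of the 4 values shown sit.

The compounds shown leave open what concentration, if any, would produce a measurable effect in this assay.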